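This account rests on a few compounds, and the source may have more. Where it says the series, first, only, none or still open, it means among the compounds named here.

Measured compounds:
Compound 1 `CC(C)(C)C1=NN(c2ccc(Br)cc2)C(c2ccc(O)cc2)C1` — 11400 nM
Compound 2 `CC(C)(C)C1=NN(c2ccc(C(F)(F)F)cc2)C(c2ccc(O)cc2)C1` — 8800 nM
Compound 3 `Cc1cccc(N2N=C(C(C)(C)C)CC2c2ccc(O)cc2)c1` — 3500 nM

Three compounds sharing one core were tested in an assay on isolated protein for inhibition of protein kinase C zeta type (Homo sapiens), with a stated time of 4 min; a lower number here means a stronger inhibitor, a higher number a weaker inhibitor. Compound 1 gives the highest number of the three. The step of a 1.3-fold lower number from compound 1 to compound 2 (0.11 log units; within the scatter) lies within the scatter, whereas a 3.3-fold lower number from compound 1 to compound 3 (0.51 log units; beyond the scatter) is a modest gain.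

Compound 4 `Oc1ccc(C2CC(c3cccs3)=NN2c2ccc(Br)cc2)cc1` has not yet been measured. It differs from compound 1 at another position: thiophen-2-yl in place of tert-butyl on a carbon with a double bond to nitrogen. Both measured steps alter the group on the ring nitrogen, so neither bears directly on an exchange at the carbon with a double bond to nitrogen. For the measured compounds named here, with no comparable step at hand, the expected change for compound 4 is a 1.3-fold lower number from compound 1 to compound 4 (0.10 log units; within the scatter), not beyond the scatter. Compound 4 is therefore estimated at 9000 nM, within a wide range from 2500 nM to 30000 nM.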

Compound 4, half-maximal inhibitory concentration: 500 nM
The estimate for compound 4 lay 18-fold (1.26 log units) above the measured number; the measured number lies below the stated range.
By their numbers in this assay, from the lowest: compound 4; then compound 3; then compounds 2 and 1 (each within the scatter of the next).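

In this assay, thiophen-2-yl in place of tert-butyl on the carbon with a double bond to nitrogen gives a 23-fold lower number from compound 1 to compound 4 (1.36 log units; beyond the scatter) and so moves the number much further than either exchange on the ring nitrogen. For the compounds shown here, the earlier compounds all carry tert-butyl here, so only this step shows how strongly this position can shift the number. Nothing measured here accounts for the gain. From the compounds shown here alone, whether phenyl, furan-2-yl or a plain methyl would do the same remains open. So does whether 3-methylphenyl on the ring nitrogen would add to this gain.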